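The source may report more compounds than this note shows. Statements on the series, on what has been measured and on what is new or still open speak of the compounds shown alone.

Working notes on the series

The shared core carries an aminoethyl linker ending in an amide, and the three measured compounds differ only in the ring on the carbonyl carbon. Compound 1 `Cc1cc(C)c2cc(C#N)c(NCCNC(=O)c3ccccn3)nc2c1` in an in vitro assay on FRT cells with Cystic fibrosis transmembrane conductance regulator variant F508del (Homo sapiens) as the target, read by fluorescence, with a stated time of 24 h, at 37 degrees C, in the presence of a further agent that is not named here (on this read-out lower numbers stand for an effect already at smaller amounts and higher numbers for an effect only at larger amounts of compound), gives "not active" (no number reported). Compound 3 `Cc1cc(C)c2cc(C#N)c(NCCNC(=O)c3ccccc3)nc2c1` in this assay likewise gives "not active" (no number reported). For the measured compounds named here, compound 2 `Cc1cc(C)c2cc(C#N)c(NCCNC(=O)c3ccncc3)nc2c1` in this assay gives 7300 nM, the only numerical result in the set; the other two entries carry no number, so no step between measured compounds can be computed here, and compound 2 stands alone as the sole point with a value.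

The next compound, compound 4 `COc1ccc(C(=O)NCCNc2nc3cc(C)cc(C)c3cc2C#N)cc1OC`, is derived from compound 2 by the change (3,4-dimethoxyphenyl in place of pyridin-4-yl on a carbonyl carbon), that is, 3,4-dimethoxyphenyl in place of pyridin-4-yl on a carbonyl carbon. Going by the values given here, the sole reference is that compound 3 with an unsubstituted carbon-only ring gives "not active" (no number reported), while compound 2 gives 7300 nM; no measured step relates these two.

The expectation is therefore a step from compound 2 to compound 4 in this assay of a 1.6-fold higher number from compound 2 to compound 4 (0.22 log units; within the scatter), in the direction of a weaker effect, with a fair chance that only a limit is reported. The estimate for compound 4 in this assay is 12000 nM, within a range of 3000 nM to 50000 nM.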

Compound 4, half-maximal effective concentration: 1500 nM
Compound 4: the middle estimate sits 8.0-fold (0.90 log units) above what was measured, outside the stated range (below it).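

In this assay, 3,4-dimethoxyphenyl in place of pyridin-4-yl on the carbonyl carbon gives a 4.9-fold lower number from compound 2 to compound 4 (0.69 log units; beyond the scatter), so a ring nitrogen is not required for a numerical result at this position, something compound 2 alone could not show. A carbon-only ring is also not enough by itself: compound 3, with an unsubstituted ring, gives "not active" (no number reported), whereas compound 4, which differs from it only in the two methoxy groups, gives 1500 nM. Steps to compound 1 and compound 3 cannot be read. Neither compound carries a number. Nothing available accounts for the lower number of compound 4.

Still open, on these data alone, is whether both methoxy groups are needed, or whether a single methoxy group, an ethoxy group or a fluorine atom on the same phenyl ring would give a comparable value in this assay. The compounds shown also leave open how a longer chain in place of the aminoethyl linker, or a carboxylic acid or an amine on the ring, would fare with the 3,4-dimethoxyphenyl or pyridin-4-yl amides.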